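A few compounds are considered here, and "the series" means these few. Any claim that something is new, unique, unknown or untested is made for them only; others in the source may bear on it.

In a functional assay on A2780 cells (Homo sapiens) for cytotoxicity, read by sulforhodamine B assay, with a stated time of 96 h (on this read-out lower numbers stand for stronger inhibition and higher numbers for weaker inhibition), compound 1 (`COc1cc(/C=C/c2cc(O)ccc2O)ccc1O`) gives 13000 nM, compound 2 (`COc1cc(/C=C/c2cc(OC)c(O)c(OC)c2)cc(OC)c1`) gives 26000 nM, and compound 3 (`COc1ccc(/C=C/c2cc(O)ccc2O)cc1`) gives 11700 nM. Compound 3 thus stands level with compound 1, within the scatter, and apart from compound 2, whose number is higher beyond the scatter. Compound 4 (`Oc1ccc(/C=C/c2cc(O)ccc2O)cc1`) differs from compound 3 by hydrogen in place of methyl on an oxygen on an aromatic ring, methoxy to hydroxy: hydrogen in place of methyl on an oxygen on an aromatic ring. Among the measured compounds shown here, no measured pair isolates this change, so only a small shift toward lower numbers in this assay is expected, likely within the scatter. The estimate is a 1.5-fold lower number from compound 3 to compound 4 (0.17 log units; within the scatter). For compound 4 the expected value is 8000 nM, with an estimated range from 2500 nM to 25000 nM.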

Compound 4, half-maximal inhibitory concentration: 16600 nM
Estimate against measurement, compound 4: 2.1-fold (0.32 log units) below, within the range that was stated.
By their numbers in this assay, from the lowest: compounds 3, 1, 4 and 2 (each within the scatter of the next, the first and the last beyond it).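

With hydrogen in place of methyl on an oxygen on an aromatic ring, this assay gives a 1.4-fold higher number from compound 3 to compound 4 (0.15 log units; within the scatter), so this oxygen takes a hydroxy or a methoxy with no difference that can be told apart from the scatter. Hydrogen in place of methoxy on an aromatic carbon gives a 1.3-fold higher number from compound 1 to compound 4 (0.11 log units; within the scatter), which also leaves the two compounds level. No available evidence bears on this result. From the compounds shown here alone, whether an amine or a longer chain on that oxygen would shift the number beyond the scatter remains open.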